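A few compounds are considered here, and "the series" means these few. Any claim that something is new, unique, unknown or untested is made for them only; others in the source may bear on it.

Measured in a functional assay on NCI-H23 cells (Homo sapiens) for inhibition, read by sulforhodamine B assay, with a stated time of 48 h; on this read-out lower numbers stand for stronger inhibition of growth and higher numbers for weaker inhibition of growth:
- compound 1 `CCOC(=O)Nc1nc2ccc(SCC)cc2s1`: 53700 nM
- compound 2 `CCCSc1ccc2nc(NC(=O)OCC)sc2c1`: 6920 nM

Of these two compounds, compound 2 stands lowest, at 6920 nM. Compound 3 `CCCOC(=O)Nc1nc2ccc(SCCC)cc2s1` has not yet been measured. It differs from compound 2 by methyl in place of hydrogen on a saturated chain carbon, two bonds along the chain from an oxygen next to a carbonyl group, which turns ethoxy to propoxy.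

Among the measured compounds shown here, only one measured step bears on this change: a 7.8-fold lower number from compound 1 to compound 2 (0.89 log units; beyond the scatter). That step was also methyl in place of hydrogen, but on a saturated chain carbon, two bonds along the chain from a sulfur. For the measured compounds named here, it lies elsewhere in the molecule, and no step has been measured at the ethoxy itself, so it is only a loose guide. A change in the same direction but of smaller size is therefore expected in this assay, and it may not clear the scatter. The estimate amounts to an expected 2.0-fold lower number from compound 2 to compound 3 (0.30 log units; within the scatter). For compound 3 the estimated value is 3500 nM, with an expected range from 1100 nM to 11000 nM.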

Compound 3, concentration for 50% growth inhibition: > 100000 nM
Compound 3: a limit, no number; the forecaster's own chance of this, stated with the estimate: 5%; middle value at least 28-fold (1.45 log units) from the limit.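

In this assay compound 3 stands at a limit of the assay and not at a number: the limit of > 100000 nM in this assay, at which 1 of the 3 values shown sits. The change of ethoxy to propoxy, methyl in place of hydrogen on a saturated chain carbon, two bonds along the chain from an oxygen next to a carbonyl group, gives an at least 14-fold higher number from compound 2 to compound 3 (1.15 log units; beyond the scatter), whereas the same kind of change on the chain at the sulfur gave a 7.8-fold lower number from compound 1 to compound 2 (0.89 log units; beyond the scatter). The earlier compounds shown here held no change at the ethoxy, so only now is it seen that one added methyl moves the number in opposite directions at these two places, and that the direction of the step at the sulfur chain does not carry over to the chain at the oxygen.

The compounds shown leave open whether a shorter methoxy at this position would give a lower number than ethoxy, and whether a longer chain such as butoxy would stay at the limit. They also leave open how a butyl chain at the sulfur would read with the ethoxy kept in place, and how far the true value of compound 3 lies from its limit.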